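The source may hold more compounds than are shown below. What is called first, only, known or untested is meant among the compounds shown, and "the series" means these compounds.

Measured compounds:
Compound 1 `O=C(CCc1cccc2c1B(O)OC2)Nc1ccc(Br)cc1` gives 9200 nM in a functional assay on SK-OV-3 cells (Homo sapiens) for antiproliferative activity, read by MTT assay, with a stated time of 72 h; a higher number here means a weaker inhibitor, a lower number a stronger inhibitor.
Compound 2 `O=C(CCc1cccc2c1B(O)OC2)Nc1cccc(Br)c1` gives 540 nM in this assay.

Going by the values given here, compound 2 has the lowest of the two numbers in this assay; its nearest neighbour is compound 1, and the single measured step, a 17-fold lower number from compound 1 to compound 2 (1.23 log units; beyond the scatter), came from moving the bromo to give 3-bromophenyl in place of 4-bromophenyl on an amide-type nitrogen. Compound 3 `COc1ccc(-c2cccc(NC(=O)CCc3cccc4c3B(O)OC4)c2)cc1` is not yet measured. It differs from compound 2 in one place: 4-methoxyphenyl in place of bromo on an aromatic carbon. Among the compounds with values here, no measured step bears on this exchange, since the only step measured concerns where the bromo sits, not what replaces it. With nothing to go on beyond the position being kept, compound 3 is expected to stay near compound 2, with the step of a 1.2-fold higher number from compound 2 to compound 3 (0.08 log units; within the scatter) not expected to go beyond the scatter in either direction. Compound 3 is therefore estimated at 650 nM, within a range of 150 nM to 3000 nM.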

Compound 3, half-maximal inhibitory concentration: 48 nM
The estimate for compound 3 lay 14-fold (1.13 log units) above the measured number; measured number below the stated range.
By their numbers in this assay, from the lowest: compound 3; then compound 2; then compound 1.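

Until now the measurements showed only that the place of the bromo on the anilide ring matters. Compound 3 shows that, in this assay, the bromo itself can be exchanged on that aromatic carbon for a much larger group that adds a whole further aromatic ring, and that this exchange gives an 11-fold lower number from compound 2 to compound 3 (1.05 log units; beyond the scatter) rather than a loss. Nothing available explains why the 4-methoxyphenyl group gives this gain.

The compounds shown leave open whether the gain depends on the methoxy group or on the added ring alone, which a plain phenyl, a 4-hydroxyphenyl or a pyridine ring at this place would help to separate. They also leave open how a longer chain between the amide carbonyl and the core would affect the number in this assay.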